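The compounds below may be only part of what the source reports. "The series", "measured", "known", "first", "only" and "open" are said of these compounds alone.

Working notes on the series. In an ADME assay on BHK-21 cells (Mesocricetus auratus) for cytotoxicity, with a stated time of 3 days (a lower number here means that less compound is tolerated, a higher number that more compound is tolerated), compound 1 `CC(Sc1nnc(-c2ccncc2)s1)C(=O)Nc1ccc(Cl)cc1Cl` gives > 50000 nM, which is a limit of the assay and not a number. Compound 2 `CC(Sc1nnc(-c2ccncc2)s1)C(=O)Nc1c(Cl)cccc1Cl` in this assay gives > 50000 nM, again a limit. Among the compounds with values here, compound 3 `O=C(CCSc1nnc(-c2ccncc2)s1)Nc1c(Cl)cccc1Cl` is the only compound with a number; in this assay compound 3 gives 10300 nM. How the core of compound 3 differs from the core of compound 2 is not broken down here.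

The change 2,4-dichlorophenyl in place of 2,6-dichlorophenyl on an amide-type nitrogen gives a step that the two limits leave unreadable from compound 2 to compound 1, a step whose size cannot be read because of the limit of > 50000 nM in this assay, at which 2 of the 3 values shown sit. Compound 4 `O=C(CCSc1nnc(-c2ccncc2)s1)Nc1ccc(Cl)cc1Cl` carries the same change, (2,4-dichlorophenyl in place of 2,6-dichlorophenyl on an amide-type nitrogen), on the core of compound 3. The step from compound 3 to compound 4 is expected to be a 1.2-fold higher number from compound 3 to compound 4 (0.07 log units; within the scatter), a small one, resting on compound 1 and compound 2 both sitting at the limit. Compound 4 is therefore estimated at 12000 nM, within 4000 nM to 50000 nM.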

Compound 4, half-maximal cytotoxic concentration: > 50000 nM
Compound 4 was reported as a limit; the forecaster's own chance of this, stated with the estimate: 30%; middle value at least 4.1-fold (0.61 log units) away from the limit.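

The change from 2,6-dichlorophenyl to 2,4-dichlorophenyl on an amide-type nitrogen gives an at least 4.8-fold higher number from compound 3 to compound 4 (0.68 log units; beyond the scatter) in this assay. From the compounds shown here alone, the matching step from compound 2 to compound 1 cannot be read, and the upper size of the new step also stays open, because of where the values sit: the limit of > 50000 nM in this assay, at which 3 of the 4 values shown sit. The result therefore shows a real step on one core, but it does not show that the change carries the same size from one core to the other.

Within the data shown here, compound 3 remains the only compound with a number, so no size can be compared between the two cores. Also open, going by these compounds, is how an unsubstituted phenyl, a 4-chlorophenyl or a carboxylic acid on that ring would read on either core.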